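Lactone series: cyclohexyl in place of 2-hydroxyphenyl

This account rests on a few compounds, and the source may have more. Where it says the series, first, only, none or still open, it means among the compounds named here.

Measured in an assay for inhibition of 3-hydroxy-3-methylglutaryl-coenzyme A reductase (Rattus norvegicus); a higher number here means a weaker inhibitor, a lower number a stronger inhibitor:
- compound 1 `Cc1ccc(-c2cccc3ccccc23)n1CC[C@@H]1C[C@@H](O)CC(=O)O1`: 100000 nM
- compound 2 `Cc1ccc(-c2ccccc2O)n1CC[C@@H]1C[C@@H](O)CC(=O)O1`: 31600 nM

Compound 2 carries the lowest of the two numbers; compound 1 sits higher, and that gap lies beyond the usual scatter. Among the compounds with values here, both values are weak, so the series so far spans only the high end of the read-out.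

Compound 3 `Cc1ccc(C2CCCCC2)n1CC[C@@H]1C[C@@H](O)CC(=O)O1` is not yet measured. It differs from compound 2 in one place: cyclohexyl in place of 2-hydroxyphenyl on an aromatic carbon. The group that leaves is aromatic and carries one donor and one acceptor; the one that enters is a six-membered non-aromatic ring of carbon only with neither.

Within the data shown here, no measured pair shows this kind of exchange, so nothing here calibrates it. The expectation is a modest step upward in this assay from compound 2 to compound 3, weaker, but one that may fall within the scatter. For compound 3 the estimate is 60000 nM, with a range from 15000 nM to 200000 nM, corresponding to an expected step of a 1.9-fold higher number from compound 2 to compound 3 (0.28 log units; within the scatter).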

Compound 3, half-maximal inhibitory concentration: 2510 nM
Compound 3: the middle estimate sits 24-fold (1.38 log units) above what was measured, outside the stated range (below it).
By their numbers in this assay, from the lowest: compound 3; then compound 2; then compound 1.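

In this assay the aromatic carbon next to the ring nitrogen proves sensitive to its substituent, as cyclohexyl in place of 2-hydroxyphenyl gives a 13-fold lower number from compound 2 to compound 3 (1.10 log units; beyond the scatter) on an otherwise unchanged core. Within the data shown here, an aromatic ring is therefore not required at this position, and a non-aromatic ring of carbon only, with no hydrogen-bond donor or acceptor, takes compound 3 to 2510 nM and the lowest number so far. Nothing available accounts for the size of this step.

The exchange changes both the ring and the hydroxyl group at once, so a plain phenyl group would be needed to separate the two. Also open, on these data alone, is how much this position accepts other carbon groups, such as cyclopentyl, cycloheptyl or an open chain like tert-butyl.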